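This account rests on a few compounds, and the source may have more. Where it says the series, first, only, none or still open, it means among the compounds named here.

In a functional assay on the whole organism (Tail, strain ICR) with Mus musculus as the target, in the tail flick test, with a stated time of 120 min, at a dose of 25 umol/kg by the oral route (on this read-out lower numbers stand for a weaker effect and higher numbers for a stronger effect at the one dose given), compound 1 `CC[C@H](C)[C@H](NC(=O)CN(c1nc(Cl)nc2[nH]cnc12)C1CC1)C(=O)O` gives 21.4%.
Compound 2 `C[C@@H](O)[C@H](NC(=O)CN(c1nc(Cl)nc2[nH]cnc12)C1CC1)C(=O)OCc1ccccc1` gives 30.7%.
Compound 3 `C[C@@H](O)[C@H](NC(=O)CN(c1nc(Cl)nc2[nH]cnc12)C1CC1)C(=O)O` gives 37.6%.

Compound 3 holds the highest of the three numbers; its nearest neighbour is compound 2, within the scatter, and its furthest is compound 1, beyond the scatter. Compound 4 `CSCC[C@H](NC(=O)CN(c1nc(Cl)nc2[nH]cnc12)C1CC1)C(=O)O` differs from compound 3 by 2-(methylsulfanyl)ethyl in place of 1-hydroxyethyl on a saturated chain carbon bound to an amide-type nitrogen and a carbonyl carbon. Going by the values given here, one measured step bears on this: a number 16.2 percentage points higher from compound 1 to compound 3 (beyond the scatter), which shows that trading the hydroxy of compound 3 for a carbon-only side chain costs a modest amount. Compound 4 also loses that hydroxy and gains a longer chain carrying sulfur, so a modest downward step is expected, about a number 12.6 percentage points lower from compound 3 to compound 4 (beyond the scatter). Compound 4 is therefore estimated at 25%, in the range 12% to 38%.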

Compound 4, a percentage reported as activity, at one dose (the size of the read-out at that dose, not a potency): 5.67%
Compound 4: the middle estimate sits 19.3 percentage points above what was measured; the whole stated range lies above it.
By their numbers in this assay, from the lowest: compound 4; then compounds 1, 2 and 3 (each within the scatter of the next, the first and the last beyond it).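

At this position, on the saturated chain carbon bound to an amide-type nitrogen and a carbonyl carbon, replacing 1-hydroxyethyl with 2-(methylsulfanyl)ethyl gives a large loss, a number 31.9 percentage points lower from compound 3 to compound 4 (beyond the scatter). Side chains without the hydroxy are not equivalent either, since 2-(methylsulfanyl)ethyl in place of sec-butyl gives a number 15.7 percentage points lower from compound 1 to compound 4 (beyond the scatter). Nothing available gives a reason for either step.

From the compounds shown here alone, it remains open how a side chain ending in an amine or a carboxylic acid would read at this place. Going by these compounds, the effect of a benzyl ester on compound 4 is also open.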